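From an Ethylazetidine Amide to a Boc-Pyrrolidine Amide

A few compounds are considered here, and "the series" means these few. Any claim that something is new, unique, unknown or untested is made for them only; others in the source may bear on it.

Compound 1 `CCN1CC(NC(=O)[C@@H]2CCCN(S(=O)(=O)c3ccc(S(=O)(=O)N(CC)CC)cc3)C2)C1` carries the shared core as a secondary amide to a 1-ethylazetidin-3-yl group. In a functional assay on BXPC-3 cells (Homo sapiens) for inhibition, read by MTT assay, with a stated time of 7 days (on this read-out higher numbers stand for weaker inhibition and lower numbers for stronger inhibition), compound 1 gives only a limit, > 30000 nM, so no number is known for it; this is the limit of > 30000 nM in this assay, at which 1 of the 3 values shown sits. Two other amides of the same core have measured numbers. Compound 2 `CCN(CC)S(=O)(=O)c1ccc(S(=O)(=O)N2CCC[C@@H](C(=O)N3CCC(c4nc(C(C)C)no4)CC3)C2)cc1` gives 300 nM in this assay. Compound 3 `CCN(CC)S(=O)(=O)c1ccc(S(=O)(=O)N2CCC[C@@H](C(=O)N3CC4(CN(C(=O)OC(C)(C)C)C4)C3)C2)cc1`, whose amide also bears a tert-butoxycarbonyl group, gives 1100 nM in this assay.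

Compound 4 `CCN(CC)S(=O)(=O)c1ccc(S(=O)(=O)N2CCC[C@@H](C(=O)N[C@H]3CCN(C(=O)OC(C)(C)C)C3)C2)cc1` is not yet measured. It differs from compound 1 in one place: 1-(tert-butoxycarbonyl)pyrrolidin-3-yl in place of 1-ethylazetidin-3-yl on an amide-type nitrogen. Among the compounds with values here, no step between measured compounds matches this change, and since compound 1 has only a limit, the size of the step cannot be fixed from the numbers. The expected direction is toward stronger inhibition, because compound 3 gives 1100 nM in this assay with a tert-butoxycarbonyl group on its amide. The step expected is an at least 10-fold lower number from compound 1 to compound 4 (1.00 log units; beyond the scatter), a move beyond the usual scatter, though it is uncertain. Compound 4 is therefore estimated to give 3000 nM in this assay, with a range from 800 nM to 15000 nM.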

Compound 4, half-maximal inhibitory concentration: 300 nM
Compound 4: the middle estimate sits 10-fold (1.00 log units) above what was measured; measured number outside the range, below it.
By their numbers in this assay, from the lowest: compounds 2 and 4 (each within the scatter of the next); then compound 3. At a limit, above all of these: compound 1.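

Replacing 1-ethylazetidin-3-yl with 1-(tert-butoxycarbonyl)pyrrolidin-3-yl on an amide-type nitrogen gives, in this assay, an at least 100-fold lower number from compound 1 to compound 4 (2.00 log units; beyond the scatter). Within the data shown here, this is the first step that can be read at this place, and it shows that a change to this one group, with the rest of the shared core untouched, is enough to take the read-out from a limit to a measured number; the earlier compounds, which differ from one another in more than one place, could not show this. The step gives only a minimum size, as the value of compound 1 is a limit and not a number: the limit of > 30000 nM in this assay, at which 1 of the 4 values shown sits.

The change replaces the ring and the group on the ring nitrogen together, so the compounds shown cannot say how much of the step belongs to the five-membered ring, to the tert-butoxycarbonyl group or to the defined stereocentre. Going by these compounds, a 1-ethylpyrrolidin-3-yl group, a 1-(tert-butoxycarbonyl)azetidin-3-yl group or a pyrrolidine with a free secondary amine at this place would separate these parts, and the opposite stereocentre remains open as well.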